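Shifting the pendant ring from pyridinyl to hydroxyphenyl

This account rests on a few compounds, and the source may have more. Where it says the series, first, only, none or still open, it means among the compounds named here.

Among the compounds with values here, compound 3 `CC(Oc1ccccc1-c1ccncc1)C1=NCCN1` gives the highest number of the three compounds measured so far: in an assay on CHO cells for displacement of a labelled ligand from Alpha-2B adrenergic receptor (Homo sapiens) (on this read-out higher numbers stand for weaker inhibition and lower numbers for stronger inhibition), compound 3 gives 2690 nM. Compound 2 `CC(Oc1ccccc1-c1cccnc1)C1=NCCN1` gives 933 nM, and compound 1 `CC(Oc1ccccc1-c1ccc([N+](=O)[O-])cc1)C1=NCCN1` gives 501 nM, so compound 3 is the weakest of the set, with both gaps beyond the scatter. Within the data shown here, the single measured step, a 2.9-fold higher number from compound 2 to compound 3 (0.46 log units; beyond the scatter), shows that moving the ring nitrogen alone changes the number modestly. Compound 4 `CC(Oc1ccccc1-c1ccccc1O)C1=NCCN1` differs from compound 3 by 2-hydroxyphenyl in place of pyridin-4-yl on an aromatic carbon. Among the measured compounds shown here, no measured step replaces a pyridinyl with a carbon-only ring bearing a hydroxyl, so the expectation rests only on the spread seen between the three measured compounds, all of which carry a six-membered aromatic ring at the same place. Compound 4 is expected to land back among the lower numbers, the estimated step being a 3.4-fold lower number from compound 3 to compound 4 (0.53 log units; beyond the scatter). Compound 4 is estimated at 800 nM, within a range from 250 nM to 2600 nM.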

Compound 4, inhibition constant: 1000 nM
Compound 4: middle estimate off by 1.3-fold (0.10 log units), on the low side; low and high end bracket the measured number.
By their numbers in this assay, from the lowest: compounds 1, 2 and 4 (each within the scatter of the next); then compound 3.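

Compound 4 shows that this position, on an aromatic carbon, can carry a carbon-only ring with a hydroxyl and still read like a pyridinyl compound. In this assay, 2-hydroxyphenyl in place of pyridin-4-yl gives a 2.7-fold lower number from compound 3 to compound 4 (0.43 log units; beyond the scatter), whereas 2-hydroxyphenyl in place of pyridin-3-yl gives a 1.1-fold higher number from compound 2 to compound 4 (0.03 log units; within the scatter), so the change separates compound 4 from compound 3 but not from compound 2. No measurement here accounts for these differences.

On these data alone, it remains open how the plain phenyl ring would read, so the share of the hydroxyl in the number of compound 4 cannot be told. As far as these compounds go, it is also open whether a methoxy group or an amine in place of that hydroxyl would leave the number where it stands.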